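A few compounds are considered here, and "the series" means these few. Any claim that something is new, unique, unknown or untested is made for them only; others in the source may bear on it.

Compound 1 `C#Cc1cccc(Nc2ncnc3cc(NC(=O)/C=C/c4ccccc4)sc23)c1` gives 2340 nM in a functional assay on MDA-MB-231 cells (Homo sapiens) for antiproliferative activity, read by MTT assay, with a stated time of 48 h; on this read-out higher numbers stand for weaker inhibition and lower numbers for stronger inhibition. Compound 2 `O=C(/C=C/c1ccccc1)Nc1cc2ncnc(Nc3cc(Cl)cc(Cl)c3)c2s1` gives 1000 nM in this assay. Compound 3 `C#Cc1cccc(Nc2ncnc3sc(NC(=O)/C=C/c4ccccc4)cc23)c1` gives 5050 nM in this assay, the highest of the three.

Compound 1 and compound 3 are built from the same atoms joined differently; the difference between the two cores is not broken down here. Going from compound 1 to compound 2, the change 3,5-dichlorophenyl in place of 3-ethynylphenyl on a nitrogen on an aromatic ring gave a 2.3-fold lower number from compound 1 to compound 2 (0.37 log units; beyond the scatter). Compound 4 `O=C(/C=C/c1ccccc1)Nc1cc2c(Nc3cc(Cl)cc(Cl)c3)ncnc2s1` is the same change applied to the core of compound 3: 3,5-dichlorophenyl in place of 3-ethynylphenyl on a nitrogen on an aromatic ring. Since the surroundings of the change are the same in both pairs, a step of similar size is expected, a 2.3-fold lower number from compound 3 to compound 4 (0.36 log units; beyond the scatter), resting on the measured 2.3-fold lower number from compound 1 to compound 2 (0.37 log units; beyond the scatter) between compound 1 and compound 2. Compound 4 is therefore estimated at 2200 nM, likely between 1000 nM and 5000 nM.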

Compound 4, half-maximal inhibitory concentration: 11500 nM
Compound 4: middle estimate off by 5.2-fold (0.72 log units), on the low side; measured number above the stated range.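

In this assay, the same swap of 3-ethynylphenyl for 3,5-dichlorophenyl gave a 2.3-fold higher number from compound 3 to compound 4 (0.36 log units; beyond the scatter), the opposite direction to the step seen on the core of compound 1. The change therefore did not carry from one core to the other, and the two steps clearly differ: the same change on two cores in this assay, a 2.3-fold lower number (0.37 log units; beyond the scatter) from compound 1 to compound 2 and a 2.3-fold higher number (0.36 log units; beyond the scatter) from compound 3 to compound 4, 5.3-fold (0.73 log units) apart, beyond the scatter of two such steps

This shows that, in these two pairs, the outcome of the swap depends on the core, but it does not show why, and two cores give no rule for a third.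

Going by these compounds, it remains open how a 3-methoxyphenyl or 3-aminophenyl group on the same nitrogen would behave on each core, and whether either would also change direction between them.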